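The source may report more compounds than this note shows. Statements on the series, on what has been measured and on what is new or still open speak of the compounds shown alone.

For the measured compounds named here, compound 2 `COc1cc2nc(N3CCN(C(=O)/C=C/c4ccc(N=C=S)cc4)CC3)nc(N)c2cc1OC` stands at the top of the two numbers measured so far in an assay on cell membranes for displacement of a labelled ligand from Adrenergic receptor alpha-1 (Rattus norvegicus), tested at 100 nM; a lower number here means a stronger inhibitor, a higher number a weaker inhibitor: compound 2 gives 102 nM, while compound 1 `COc1cc2nc(N3CCN(C(=O)/C=C/c4ccccc4)CC3)nc(N)c2cc1OC` gives 0.692 nM. Compound 3 `COc1cc2nc(N3CCN(C(=O)/C(F)=C/c4ccccc4)CC3)nc(N)c2cc1OC` has not yet been measured. From compound 2 to compound 3 the change is a group of 9 heavy atoms (8 carbon, 1 fluorine; one six-membered aromatic ring of carbon only) in place of a group of 11 heavy atoms (9 carbon, 1 nitrogen, 1 sulfur; one six-membered aromatic ring of carbon only), on a carbonyl carbon. In plain terms, the group that carries nitrogen and sulfur on its aromatic ring is taken out, and a 1-fluoro-2-phenylethenyl group takes its place on that carbonyl carbon. Going by the values given here, one measured step bears on this: a 150-fold higher number from compound 1 to compound 2 (2.17 log units; beyond the scatter). Among the compounds with values here, compound 3 undoes that addition, but it also brings one fluorine onto the double bond, a change on which no measured pair gives any guidance. The expected step is therefore a 100-fold lower number from compound 2 to compound 3 (2.01 log units; beyond the scatter), close in size to the measured step but in the opposite direction, with extra uncertainty from the fluorine. Compound 3 is estimated at 1 nM, within a range of 0.3 nM to 6 nM.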

Compound 3, half-maximal inhibitory concentration: 39.8 nM
Estimate against measurement, compound 3: 40-fold (1.60 log units) below; the whole stated range lies below it.
By their numbers in this assay, from the lowest: compound 1; then compound 3; then compound 2.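

In this assay, for the compounds shown here, the single fluorine that turns 2-phenylethenyl into 1-fluoro-2-phenylethenyl on the carbonyl carbon is far from a silent swap: it gives a 58-fold higher number from compound 1 to compound 3 (1.76 log units; beyond the scatter) and is the only change here that leaves the aromatic ring as it was. The earlier pair showed sensitivity only to a group added on that aromatic ring, whereas this step shows that the number also responds strongly to a change on the ethenyl part of the group. The other step, a 2.6-fold lower number from compound 2 to compound 3 (0.41 log units; beyond the scatter), is much smaller than either step away from compound 1, so removing the nitrogen and sulfur group while adding the fluorine recovers only a small part of the ground held by compound 1.

Going by these compounds, it remains open whether a methyl group or a chlorine atom in place of that fluorine would raise the number as much, or whether a fluorine on the aromatic ring instead would do the same. No independent measurement is at hand that could account for the size of either step.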